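The source may hold more compounds than are shown below. What is called first, only, known or untested is meant among the compounds shown, and "the series" means these compounds.

In a functional assay on HT-29 cells (Homo sapiens) for inhibition, read by sulforhodamine B assay, with a stated time of 72 h (on this read-out higher numbers stand for weaker inhibition and lower numbers for stronger inhibition), compound 3 (`C=CC1C(=O)N(c2cc(OC)c(OC)c(OC)c2)C1c1ccc(SCC)cc1`) gives 257 nM. This value lies within the scatter of compound 2 (`CCSc1ccc(C2CC(=O)N2c2cc(OC)c(OC)c(OC)c2)cc1`) at 311 nM, while compound 1 (`COc1ccc(C2C(O)C(=O)N2c2cc(OC)c(OC)c(OC)c2)cc1`) gives a much lower number, 12 nM. The step followed here leads to compound 4 (`C=CC1C(=O)N(c2cc(OC)c(OC)c(OC)c2)C1c1ccc(OC)cc1`), with methoxy in place of ethylsulfanyl on an aromatic carbon, para to a large group: methoxy in place of ethylsulfanyl on an aromatic carbon. Among the compounds with values here, no measured step makes this exchange. Within the data shown here, the only measured step, a 1.2-fold lower number from compound 2 to compound 3 (0.08 log units; within the scatter), puts vinyl in place of hydrogen on a saturated ring carbon and stays within the scatter, so it says nothing direct about the exchange. The nearest evidence is compound 1, which carries the 4-methoxyphenyl group and reads 12 nM, although it has hydroxy rather than vinyl on the ring carbon. A clear move towards a lower number in this assay is therefore expected, on indirect evidence. The estimated step is a 6.4-fold lower number from compound 3 to compound 4 (0.81 log units; beyond the scatter). Compound 4 is expected at 40 nM, with an estimated range of 8 nM to 200 nM.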

Compound 4, half-maximal inhibitory concentration: 10 nM
The estimate for compound 4 lay 4.0-fold (0.60 log units) above the measured number, within the range that was stated.
By their numbers in this assay, from the lowest: compounds 4 and 1 (each within the scatter of the next); then compounds 3 and 2 (each within the scatter of the next).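

In this assay, the exchange of 4-(ethylsulfanyl)phenyl for 4-methoxyphenyl gives a 26-fold lower number from compound 3 to compound 4 (1.41 log units; beyond the scatter) and is the one step shown at this aromatic carbon, a large change where vinyl in place of hydrogen on the saturated ring carbon had stayed within the scatter. With 4-methoxyphenyl in place, vinyl and hydroxy on the saturated ring carbon do not separate, giving a 1.2-fold lower number from compound 1 to compound 4 (0.08 log units; within the scatter) and so showing that both groups are compatible with a low number. Nothing measured here explains the size of the exchange on the aromatic carbon.

The exchange alters both the atom attached to the ring and the chain, so the compounds shown cannot separate the two changes. Methylsulfanyl or ethoxy at this place would separate them, while an amine remains open as another group there.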